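The compounds below may be only part of what the source reports. "The series", "measured", "known", "first", "only" and "open" are said of these compounds alone.

Compound 2 `O=C(CCl)Nc1ccc(I)cc1` gives 6200 nM in a functional assay on MCF7 cells (Homo sapiens) for antiproliferative activity, with a stated time of 48 h (on this read-out lower numbers stand for stronger inhibition and higher numbers for weaker inhibition), the higher of the two numbers shown. Compound 3 `CC(C)(C)c1ccc(NC(=O)CCl)cc1` gives 5400 nM in this assay, and the step of a 1.1-fold lower number from compound 2 to compound 3 (0.06 log units; within the scatter) lies within the scatter. Compound 1 `CCNC(=O)NCc1ccc(C(C)(C)C)cc1` gives > 100000 nM in this assay, which is a limit of the assay (the limit of > 100000 nM in this assay, at which 1 of the 3 values shown sits). Compound 4 `C=CC(=O)Nc1ccc(I)cc1` differs from compound 2 by vinyl in place of chloromethyl on a carbonyl carbon. Neither measured step bears on this change: the step from compound 2 to compound 3 concerns the group on an aromatic carbon, and compound 1 differs from compound 4 in more than one place. No step beyond the scatter is therefore expected in this assay, and the estimated step of a 1.0-fold lower number from compound 2 to compound 4 (0.01 log units; within the scatter) says as much. Compound 4 is expected to give about 6000 nM, between 1500 nM and 25000 nM.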

Compound 4, half-maximal inhibitory concentration: 17000 nM
The estimate for compound 4 lay 2.8-fold (0.45 log units) below the measured number, within the range that was stated.
By their numbers in this assay, from the lowest: compounds 3 and 2 (each within the scatter of the next); then compound 4. At a limit, above all of these: compound 1.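

In this assay, vinyl in place of chloromethyl on a carbonyl carbon gives a 2.7-fold higher number from compound 2 to compound 4 (0.44 log units; beyond the scatter) and so moves the number beyond the scatter. Among the compounds shown here, this is the first look at this position, as the earlier step, a 1.1-fold lower number from compound 2 to compound 3 (0.06 log units; within the scatter), concerned the group on an aromatic carbon. Within this pair, the chloromethyl compound 2 holds the lower number.

Open, from the compounds shown here alone, is how an aminomethyl group or a longer chain on this carbonyl carbon would compare, and whether the step holds with tert-butyl on the aromatic carbon. Nothing at hand bears on what lies behind this step.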